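The source may hold more compounds than are shown below. What is called first, only, known or untested is meant among the compounds shown, and "the series" means these compounds.

Among the measured compounds shown here, in a functional assay on OVCAR-5 cells (Homo sapiens) for inhibition, read by sulforhodamine B assay, with a stated time of 48 h (a lower number here means that less compound is tolerated, a higher number that more compound is tolerated), compound 3 `Nc1cc(N)c2nc(-c3ccccc3)c(Sc3ccc(Cl)c(Cl)c3)nc2c1` gives 91200 nM, the only plain number among the three measured compounds. Compound 1 `Nc1cc(N)c2nc(-c3ccccc3)c(NCc3ccc(F)cc3)nc2c1` reaches only a limit of the assay, < 100000 nM. Compound 2 `COc1ccc(Sc2nc3cc(N)cc(N)c3nc2-c2ccccc2)cc1` likewise reaches only a limit, < 100000 nM. the limit of < 100000 nM in this assay, at which 2 of the 3 values shown sit, keeps the steps among these three from being read: a step that the two limits leave unreadable from compound 1 to compound 2, a step that the limit leaves unreadable from compound 1 to compound 3 and a step that the limit leaves unreadable from compound 2 to compound 3 all stand without a size. Compound 4 `Nc1cc(N)c2nc(-c3ccccc3)c(Sc3ccc(F)cc3)nc2c1` has not yet been measured in this assay. It differs from compound 3 in one place: 4-fluorophenyl in place of 3,4-dichlorophenyl on a sulfur. For the measured compounds named here, the step that the limit leaves unreadable from compound 2 to compound 3 also changes the group on the sulfur, but it leaves no size to carry over, so no measured step gives a direction for the new change, and nothing beyond the scatter can be called for on that ground. Compound 3 itself sits close to the limit at which its two companions stop, which leaves little room for a readable result. Compound 4 is therefore expected to give 120000 nM in this assay, within 60000 nM to 250000 nM, most likely as a limit rather than a number. The step this expectation implies is estimated at a 1.3-fold higher number from compound 3 to compound 4 (0.12 log units; within the scatter).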

Compound 4, concentration lethal to 50% of the cells: < 100000 nM
Compound 4: only a limit was reported; the forecaster's own chance of this, stated with the estimate: 60%; middle value at least 1.2-fold (0.07 log units) from the limit.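

In this assay compound 4 gives only a limit of the assay, < 100000 nM. No step linking compound 4 with compound 1, compound 2 or compound 3 can be read, because the values stop at that limit: the limit of < 100000 nM in this assay, at which 3 of the 4 values shown sit.

The compounds shown leave open whether changing the group on the sulfur shifts this read-out at all.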